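The source may hold more compounds than are shown below. What is called first, only, known or untested is meant among the compounds shown, and "the series" means these compounds.

Compound 1, `CCCCOC(=O)CC1c2cccc(C)c2S(=O)(=O)N1C(C)=O`: in an assay on HEK-Blue hNOD1 cells for antagonist activity at Nucleotide-binding oligomerization domain-containing protein 1 (Homo sapiens), read by reporter gene assay, with stated times of 3 h and 20 h (on this read-out higher numbers stand for weaker inhibition and lower numbers for stronger inhibition), compound 1 gives "not determined" (no result reported).
Compound 2, `CCCCOC(=O)CC1c2cccc(C)c2S(=O)(=O)N1C(=O)c1cccc(C(F)(F)F)c1`: in this assay compound 2 gives 1050 nM.

For the measured compounds named here, compound 2 is the only compound with a number in this assay; compound 1 has no result, so nothing can be said about how the two compare. Compound 3, `CCCCOC(=O)CC1c2cccc(C)c2S(=O)(=O)N1C(=O)c1ccccc1C(F)(F)F`, is not yet measured. It differs from compound 2 in one place: 2-(trifluoromethyl)phenyl in place of 3-(trifluoromethyl)phenyl on a carbonyl carbon. The two compounds share every atom, joined differently.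

Going by the values given here, no measured pair shows what such a move of the trifluoromethyl group does here, so no direction is known from data. Compound 3 is expected to land close to compound 2, with any change a 1.1-fold higher number from compound 2 to compound 3 (0.06 log units; within the scatter) as likely as none beyond the scatter. The estimate for compound 3 in this assay is 1200 nM, within a range from 400 nM to 4000 nM.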

Compound 3, half-maximal inhibitory concentration: 1100 nM
Estimate against measurement, compound 3: 1.1-fold (0.04 log units) above; low and high end bracket the measured number.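

Placing 2-(trifluoromethyl)phenyl instead of 3-(trifluoromethyl)phenyl on the carbonyl carbon gives, in this assay, a 1.0-fold higher number from compound 2 to compound 3 (0.02 log units; within the scatter). This first measured pair at this position shows that the read-out does not separate these two attachments of the trifluoromethyl group, so the swap is tolerated here. No supporting measurement offers an explanation for this result.

Both measured compounds carry a trifluoromethyl group on the phenyl ring, so they cannot show whether that group matters at all, and compound 1, with its smaller acetyl group, has no result to compare. Going by these compounds, it remains open how a plain phenyl, a phenyl bearing a nitrile or a carboxylic acid, or a pyridine ring in the same place would read in this assay.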